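Chloro for fluoro on the terminal phenyl ring

A few compounds are considered here, and "the series" means these few. Any claim that something is new, unique, unknown or untested is made for them only; others in the source may bear on it.

Compound 2 `O=C(N/N=C/c1ccc(F)cc1)c1cccnc1Nc1cccc(C(F)(F)F)c1` stands lowest of the two numbers measured in a functional assay on the whole organism (strain Wistar) for inhibition, with Rattus norvegicus as the target, read by paw edema, with a stated time of 30 min, at a dose of 10 mg/kg by the intraperitoneal route (a higher number here means more inhibition at the dose given (going by the name of the read-out), a lower number less inhibition), giving 33.9%; compound 1 `O=C(N/N=C/c1ccccc1)c1cccnc1Nc1cccc(C(F)(F)F)c1` gives 60.4%, and the step of a number 26.5 percentage points lower from compound 1 to compound 2 (beyond the scatter) separates them. Compound 3 `O=C(N/N=C/c1cccc(Cl)c1)c1cccnc1Nc1cccc(C(F)(F)F)c1` differs from compound 2 by 3-chlorophenyl in place of 4-fluorophenyl on a carbon with a double bond to nitrogen. For the measured compounds named here, no measured step covers a chloro in place of fluoro or a shift of the substituent on that ring; the single known step, fluoro in place of hydrogen, lowered inhibition. Without a direct precedent, compound 3 is expected near compound 2, with an expected step of a number 6.1 percentage points higher from compound 2 to compound 3 (within the scatter) inside the scatter. Compound 3 is estimated at 40%, with a range from 20% to 65%.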

Compound 3, a percentage reported as inhibition, in the whole organism at one dose (the size of the read-out at that dose, not a potency): 77.8%
Beside the measured number, compound 3's estimate is 37.8 percentage points below it; the whole stated range lies below it.
By their numbers in this assay, from the lowest: compound 2; then compound 1; then compound 3.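

In this assay the step is a number 17.4 percentage points higher from compound 1 to compound 3 (beyond the scatter), whereas the fluoro analogue gave a number 26.5 percentage points lower from compound 1 to compound 2 (beyond the scatter), so a halogen on this terminal phenyl ring does not lower inhibition as such. Putting 3-chlorophenyl in place of 4-fluorophenyl gives a number 43.9 percentage points higher from compound 2 to compound 3 (beyond the scatter), showing that this position can swing the paw edema read-out widely in either direction. Nothing on hand explains the rise.

Halogen identity and ring placement change together in compound 3, so their separate contributions remain open. Also open, going by these compounds, is how a methoxy group or an amine on this ring would compare.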